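Inverting one ring stereocentre of compound 3

The source may hold more compounds than are shown below. What is called first, only, known or untested is meant among the compounds shown, and "the series" means these compounds.

Measured in an ADME assay on HFF cells (Homo sapiens) for cytotoxicity, read by neutral red uptake; on this read-out higher numbers stand for lower toxicity in this test and lower numbers for higher toxicity in this test:
- compound 1 `Nc1ncnc2c1ncn2/C=C1\C[C@@H]1[C@H](O)CO`: > 300000 nM, a limit
- compound 2 `Nc1ncnc2c1ncn2/C=C1\C[C@@H]1[C@@H](O)CO`: > 300000 nM, a limit
- compound 3 `Nc1ncnc2c1ncn2/C=C1/C[C@H]1[C@@H](O)CO`: 194000 nM

Among the compounds with values here, compound 3 carries the only actual number in this assay, as the other two entries are limits. The next compound is compound 4 `Nc1ncnc2c1ncn2/C=C1/C[C@@H]1[C@@H](O)CO`. The change to it reads: the two compounds have the same atoms and bonds and differ only in configuration as drawn: 1 of 3 stereo elements differ; a stereocentre at a saturated ring carbon is drawn R in compound 3 and S in compound 4.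

Within the data shown here, three measured steps bear on this. The first is an at least 1.5-fold lower number from compound 1 to compound 3 (0.18 log units; that floor lies within the scatter). The second is an at least 1.5-fold lower number from compound 2 to compound 3 (0.18 log units; that floor lies within the scatter). Both change the ring stereocentre together with the double bond, so neither isolates the ring stereocentre. The third is a step that the two limits leave unreadable from compound 1 to compound 2, and it concerns only the chain stereocentre. No step beyond the scatter is therefore expected in this assay, and the expected change is a 1.1-fold higher number from compound 3 to compound 4 (0.05 log units; within the scatter). For compound 4 the estimated value is 220000 nM, with an expected range of 110000 nM to 400000 nM.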

Compound 4, half-maximal cytotoxic concentration: > 300000 nM
Compound 4 was reported as a limit; the forecaster's own chance of this, stated with the estimate: 40%; at least 1.3-fold (0.13 log units) between middle value and limit.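

Within the data shown here, compound 4 gives the first pair that changes the ring stereocentre alone, and in this assay this shows an at least 1.5-fold higher number from compound 3 to compound 4 (0.18 log units; that floor lies within the scatter), so no effect of that stereocentre is established beyond the scatter. Compound 4 is reported only as a limit, > 300000 nM. The steps joining compound 4 to compounds 1 and 2 cannot be read, so the double bond geometry, the only difference between compounds 2 and 4, also has no readable size, and compound 3 remains the only entry with a number: the limit of > 300000 nM in this assay, at which 3 of the 4 values shown sit.

Still open, on these data alone, is how far compounds 1, 2 and 4 actually lie from compound 3, since their limits give no numbers. Also open, as far as these compounds go, is whether an amine or a carboxylic acid in place of the chain hydroxyl groups would give a step beyond the scatter in this assay.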